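A few compounds are considered here, and "the series" means these few. Any claim that something is new, unique, unknown or untested is made for them only; others in the source may bear on it.

Compound 1 `COC(=O)c1ccc(NCc2cncn2Cc2ccccc2Cl)cc1-c1ccccc1`: in a toxicity assay on NIH3T3 cells (Mus musculus) for cytotoxicity, read by resazurin assay (a higher number here means that more compound is needed for the effect, a lower number that less compound is needed), compound 1 gives 10000 nM.
Compound 2 `COC(=O)c1ccc(NCc2cncn2Cc2ccc(N)cc2)cc1-c1ccccc1`: in this assay compound 2 gives > 10000 nM, a limit of the assay rather than a number.
Compound 3 `COC(=O)c1ccc(NCc2cncn2Cc2cccc(Br)c2)cc1-c1ccccc1`: in this assay compound 3 gives > 10000 nM, likewise a limit.

Compound 3 therefore stands at the limit of this assay, and (the limit of > 10000 nM in this assay, at which 2 of the 3 values shown sit); there is no number to place it against compound 1 or compound 2. The steps of a number no lower from compound 1 to compound 2 (the limit leaves the size open) and a number no lower from compound 1 to compound 3 (the limit leaves the size open) are open at one end, and the step that the two limits leave unreadable from compound 2 to compound 3 cannot be read. Compound 4 `COC(=O)c1ccc(NCc2cncn2Cc2cccc(C(C)(C)C)c2)cc1-c1ccccc1` differs from compound 3 by tert-butyl in place of bromo on an aromatic carbon. Among the compounds with values here, no measured step covers this exchange. With every value shown at or beside the limit, compound 4 is expected to remain there, the expected step being a number no higher from compound 3 to compound 4 (the limit leaves the size open), nothing beyond the scatter. The estimate for compound 4 in this assay is 10000 nM, within 4000 nM to 30000 nM.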

Compound 4, half-maximal effective concentration: > 1000 nM
Compound 4: no number, only a limit; the forecaster's own chance of this, stated with the estimate: 70%; the middle value lies beyond the limit too.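

In this assay compound 4 gives > 1000 nM, a limit and not a number, so its steps from compound 1, compound 2 and compound 3 cannot be read. The compounds shown leave open how far any of these phenyl exchanges moves the value.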